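From bromo to fluoro on compound 1

The compounds below may be only part of what the source reports. "The series", "measured", "known", "first", "only" and "open" are said of these compounds alone.

In a functional assay on T98G cells (Homo sapiens) for inhibition, read by MTT assay, with a stated time of 72 h (a higher number here means a weaker inhibitor, a lower number a stronger inhibitor), compound 1 (`CC1(C)CC(NC(=O)NCc2ccccc2)c2cc(Br)ccc2O1`) gives 38000 nM while compound 2 (`CC1(C)CC(NC(=O)Nc2ccc(Cl)cc2)c2cc(Br)ccc2O1`) gives 27000 nM and the two stand level within the scatter. Going by the values given here, compound 1 therefore has no clear place at either end of this small set, and compound 2 is its only measured neighbour.

Compound 3 (`CC1(C)CC(NC(=O)NCc2ccccc2)c2cc(F)ccc2O1`) differs from compound 1 in one place, with fluoro in place of bromo on an aromatic carbon of the shared core: fluoro in place of bromo on an aromatic carbon is the whole difference.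

Among the compounds with values here, the one measured step is a 1.4-fold lower number from compound 1 to compound 2 (0.15 log units; within the scatter) and it concerns an amide-type nitrogen, not the halogen. Within the data shown here, it stays within the scatter, but it is only a weak guide, since no measured pair tests an exchange of bromo for fluoro. The data give no basis for a direction in this assay and the expected change is no larger than the scatter. The estimated step is a 1.1-fold higher number from compound 1 to compound 3 (0.02 log units; within the scatter) and this size carries little weight as a direction. The expected value for compound 3 is 40000 nM with 20000 nM to 80000 nM as its estimated range.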

Compound 3, half-maximal inhibitory concentration: 49000 nM
Estimate against measurement, compound 3: 1.2-fold (0.09 log units) below, within the range that was stated.
By their numbers in this assay, from the lowest: compounds 2, 1 and 3 (each within the scatter of the next).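

In this assay, going by these compounds alone, the exchange of bromo for fluoro on an aromatic carbon of the shared core gives a 1.3-fold higher number from compound 1 to compound 3 (0.11 log units; within the scatter) and so provides the first measured step at this position, since the earlier step concerned only the amide-type nitrogen. With the benzyl group held constant, this step lies within the scatter, so bromo and fluoro cannot be told apart here in this one pair. No measured information on these compounds bears on this result or offers an account of it.

As far as these compounds go, whether a group other than a halogen on the same aromatic carbon, such as an amine, a carboxylic acid or a methoxy group, would give a step beyond the scatter remains open. From the compounds shown here alone, it is also open whether the same exchange of bromo for fluoro would stay within the scatter on compound 2, which carries 4-chlorophenyl in place of benzyl on the amide-type nitrogen.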